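Trading the Benzyl Ring for an Ester Chain

The source may hold more compounds than are shown below. What is called first, only, known or untested is meant among the compounds shown, and "the series" means these compounds.

Compound 2 `CC(C)(C)c1ccc(/C(=C/C(=O)Nc2ccc3c(c2)OCCO3)Cc2ccccc2)cc1` gives 110 nM in a functional assay on CHO cells for inhibition of transient receptor potential cation channel subfamily V member 1 (Homo sapiens) (on this read-out lower numbers stand for stronger inhibition and higher numbers for weaker inhibition), the lower of the two numbers measured, while compound 1 `CC(C)(C)c1ccc(/C(=C/C(=O)Nc2ccc3c(c2)OCCO3)c2ccncc2)cc1` gives 660 nM. Among the compounds with values here, the one measured step, a 6.0-fold lower number from compound 1 to compound 2 (0.78 log units; beyond the scatter), touched the same chain carbon but exchanged one aromatic ring for another. Within the data shown here, compound 3 `CCOC(=O)CC/C(=C\C(=O)Nc1ccc2c(c1)OCCO2)c1ccc(C(C)(C)C)cc1` carries (ethoxycarbonyl)methyl in place of phenyl on a saturated chain carbon bound to a double-bonded chain carbon, which removes the aromatic ring altogether, a change no measured step mirrors. Compound 3 is expected to show a modest weakening, a 2.7-fold higher number from compound 2 to compound 3 (0.44 log units; beyond the scatter), with wide uncertainty. For compound 3 the estimate is 300 nM, within 100 nM to 1000 nM.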

Compound 3, half-maximal inhibitory concentration: 290 nM
Compound 3: the middle estimate sits 1.0-fold (0.01 log units) above what was measured; the measured number falls inside the stated range.
By their numbers in this assay, from the lowest: compound 2; then compound 3; then compound 1.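

The aromatic ring at this position can be given up at a modest cost: with (ethoxycarbonyl)methyl in place of phenyl, inhibition in this assay persists, with only a small loss (a 2.6-fold higher number from compound 2 to compound 3 (0.42 log units; beyond the scatter)). The same chain, read as 2-(ethoxycarbonyl)ethyl, also improves on pyridin-4-yl (a 2.3-fold lower number from compound 1 to compound 3 (0.36 log units; beyond the scatter)), so a ring-free group can outperform one of the ring-bearing groups. Nothing measured here explains either step.

Still open, as far as these compounds go, is whether the ester matters or simply the chain, a question that a carboxylic acid, an amine or a longer chain at this position could help answer.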